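Exposure notes: compound 2 to compound 3

The source may report more compounds than this note shows. Statements on the series, on what has been measured and on what is new or still open speak of the compounds shown alone.

Measured in an ADME assay on the whole organism (Rattus norvegicus, strain Sprague-Dawley) for pharmacokinetics, read by LC-MS, with a stated time of 24 h, at a dose of 1 mg/kg by the intravenous route; on this read-out higher numbers stand for higher exposure at the dose given and lower numbers for lower exposure:
- compound 1 `CCN1C(=O)COc2c(CN3CCN(C(C)=O)CC3)cc(Nc3ncc(F)c(-c4ccc(F)cc4OC)n3)cc21`: 334 ng.h/mL
- compound 2 `CCN1C(=O)COc2c(CN3CCN(S(C)(=O)=O)CC3)cc(Nc3ncc(F)c(-c4ccc(F)cc4OC)n3)cc21`: 245 ng.h/mL

The two values lie within the scatter of each other, so compound 2 stands level with compound 1. Compound 3 `CCN(CC)Cc1cc(Nc2ncc(F)c(-c3ccc(F)cc3OC)n2)cc2c1OCC(=O)N2CC` is not yet measured. It differs from compound 2 at one place: diethylamino in place of 4-(methylsulfonyl)piperazin-1-yl on a saturated chain carbon bound to an aromatic carbon.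

Among the measured compounds shown here, one measured step bears on this change: a 1.4-fold lower number from compound 1 to compound 2 (0.13 log units; within the scatter). That step kept the ring and altered only the group on its amine nitrogen, whereas here the whole ring leaves, so it is a weak guide. For the measured compounds named here, with no larger step measured, the expectation stays anchored on compound 2 at 245 ng.h/mL, leaning slightly lower in this assay, with a wide range. The expected step is a 1.4-fold lower number from compound 2 to compound 3 (0.16 log units; within the scatter). For compound 3 the estimated value is 170 ng.h/mL, with an expected range of 70 ng.h/mL to 400 ng.h/mL.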

Compound 3, area under the concentration-time curve: 107 ng.h/mL
Estimate against measurement, compound 3: 1.6-fold (0.20 log units) above, within the range that was stated.
By their numbers in this assay, from the lowest: compound 3; then compounds 2 and 1 (each within the scatter of the next).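

In this assay, the position on the saturated chain carbon bound to an aromatic carbon now shows a step beyond the scatter when the ring itself leaves and open-chain diethylamino enters (a 2.3-fold lower number from compound 2 to compound 3 (0.36 log units; beyond the scatter)), and the same change from the acetyl-bearing ring gives a similar reading (a 3.1-fold lower number from compound 1 to compound 3 (0.49 log units; beyond the scatter)). Exchanging only the group on the ring's amine nitrogen, acetyl for methylsulfonyl, stayed within the scatter, so among these three compounds the larger exchange at this position is the one that registers in exposure. Nothing at hand accounts for the lower number.

The compounds shown leave open whether the drop follows the loss of the ring, of its second nitrogen, or of the acyl or sulfonyl group. A morpholine or piperidine at this position, with a ring kept but that nitrogen gone, would help separate these readings.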